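Para-substituted benzoyl thioureas: cytotoxicity on Huh-7 cells

This account rests on a few compounds, and the source may have more. Where it says the series, first, only, none or still open, it means among the compounds named here.

Measured so far:
compound 1 `O=C(NC(=S)N1CCc2c(OCCCCCOc3ccc(Cl)cc3)cccc21)c1ccc([N+](=O)[O-])cc1` — 13600 nM
compound 2 `N#Cc1ccc(C(=O)NC(=S)N2CCc3c(OCCCCCOc4ccc(Cl)cc4)cccc32)cc1` — > 50000 nM (a limit of the assay)
compound 3 `CC(C)(C)c1ccc(C(=O)NC(=S)N2CCc3c(OCCCCCOc4ccc(Cl)cc4)cccc32)cc1` — > 50000 nM (a limit of the assay)

In an ADME assay on Huh-7 cells (Homo sapiens) for cytotoxicity (on this read-out lower numbers stand for higher toxicity in this test and higher numbers for lower toxicity in this test), compound 1 gives 13600 nM. Compound 2 gives > 50000 nM, which is a limit of the assay. Compound 3 likewise gives > 50000 nM, a limit of the assay. Both variations on the nitro of compound 1 move in the same direction: an at least 3.6-fold higher number from compound 1 to compound 2 (0.56 log units; beyond the scatter) and an at least 3.6-fold higher number from compound 1 to compound 3 (0.56 log units; beyond the scatter). The step that the two limits leave unreadable from compound 2 to compound 3 cannot be read because of the limit of > 50000 nM in this assay, at which 2 of the 3 values shown sit.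

Compound 4 `CN(C)c1ccc(C(=O)NC(=S)N2CCc3c(OCCCCCOc4ccc(Cl)cc4)cccc32)cc1` differs from compound 3 by dimethylamino in place of tert-butyl on an aromatic carbon. Within the data shown here, no measured step involves dimethylamino, so the two steps from compound 1 are the only bearing evidence, and both show the nitro compound as the toxic one while the others sit at the limit. Compound 4 is therefore expected to give 50000 nM, with a range of 20000 nM to 120000 nM, most probably again reported as a limit. The expected step is a number no higher from compound 3 to compound 4 (the limit leaves the size open).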

Compound 4, half-maximal cytotoxic concentration: > 50000 nM
Compound 4: a limit, no number (the forecaster's own chance of this, stated with the estimate: 60%); the middle value sits exactly at the limit.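

In this assay, dimethylamino in place of nitro gives an at least 3.6-fold higher number from compound 1 to compound 4 (0.56 log units; beyond the scatter), the same direction as the two earlier replacements of nitro. Compound 4 gives > 50000 nM, which is a limit of the assay, so among the four groups shown at this position, only the nitro of compound 1 gives a number, and that pattern now covers three different replacements. The steps among compound 2, compound 3 and compound 4 cannot be read, because of this: the limit of > 50000 nM in this assay, at which 3 of the 4 values shown sit.

As far as these compounds go, whether a primary amine, a carboxylic acid or a fluorine at this position would also give a limit, or a number as the nitro does, stays open. From the compounds shown here alone, how far compound 2, compound 3 and compound 4 differ from one another in this read-out also stays open.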